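From 4-bromophenyl to 3-(trifluoromethyl)phenyl: the step to compound 4

This account rests on a few compounds, and the source may have more. Where it says the series, first, only, none or still open, it means among the compounds named here.

Measured in a functional assay on MCF7 cells (Homo sapiens) for inhibition, read by MTT assay, with a stated time of 72 h; a lower number here means a stronger inhibitor, a higher number a weaker inhibitor:
compound 1 `COc1cc(NC(C)CCCNC(=O)NNC(=O)Nc2ccc(F)cc2)c2ncccc2c1` gives 310 nM
compound 2 `COc1cc(NC(C)CCCNC(=O)NNC(=O)Nc2ccc(Cl)cc2)c2ncccc2c1` gives 180 nM
compound 3 `COc1cc(NC(C)CCCNC(=O)NNC(=O)Nc2ccc(Br)cc2)c2ncccc2c1` gives 100 nM

Compound 3 stands at the low end of these three numbers, but not alone. The measured gaps are a 1.8-fold lower number from compound 2 to compound 3 (0.26 log units; within the scatter) and a 3.1-fold lower number from compound 1 to compound 3 (0.49 log units; beyond the scatter).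

Compound 4 `COc1cc(NC(C)CCCNC(=O)NNC(=O)Nc2cccc(C(F)(F)F)c2)c2ncccc2c1` is still unmeasured. Its change is 3-(trifluoromethyl)phenyl in place of 4-bromophenyl on an amide-type nitrogen, which puts 3-(trifluoromethyl)phenyl in place of 4-bromophenyl on an amide-type nitrogen. Among the measured compounds shown here, no measured compound carries this group, so no step covers the exchange directly. The closest evidence comes from the exchanges of one halogen for another, namely a 1.7-fold lower number from compound 1 to compound 2 (0.24 log units; within the scatter) and the larger gap already given for compound 1 and compound 3. Both are small to modest, so a step of no greater size is expected in this assay, leaning toward a higher number. The expected step is a 1.7-fold higher number from compound 3 to compound 4 (0.23 log units; within the scatter) as estimated here. Compound 4 is estimated at 170 nM, with an expected range from 60 nM to 450 nM.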

Compound 4, half-maximal inhibitory concentration: 190 nM
Compound 4: middle estimate off by 1.1-fold (0.05 log units), on the low side; the measured number falls inside the stated range.
By their numbers in this assay, from the lowest: compounds 3, 2, 4 and 1 (each within the scatter of the next, the first and the last beyond it).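

In this assay, putting 3-(trifluoromethyl)phenyl on the amide-type nitrogen gives steps within the scatter from all three halogen-bearing compounds (a 1.9-fold higher number from compound 3 to compound 4 (0.28 log units; within the scatter)) (a 1.1-fold higher number from compound 2 to compound 4 (0.02 log units; within the scatter)) (a 1.6-fold lower number from compound 1 to compound 4 (0.21 log units; within the scatter)). The earlier compounds shown here differed only in which halogen the phenyl carried, whereas compound 4 shows that a trifluoromethyl group, named at a different ring position, also gives a value in the same range, so a 4-halogen is not required at this position for these compounds. Nothing measured on these compounds bears on the reason for this result.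

The compounds shown leave open how much of the result belongs to the trifluoromethyl group and how much to its place on the ring, a question that 4-(trifluoromethyl)phenyl would address. Also open, going by these compounds, is how this position responds to a phenyl carrying an amine or a carboxylic acid.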